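This account rests on a few compounds, and the source may have more. Where it says the series, first, only, none or still open, it means among the compounds named here.

Compound 1 `Cc1coc2cc(-c3cccc(O)c3)oc(=O)c12` gives 82.6 uM
Compound 2 `Cc1coc2cc(-c3ccc(O)c(O)c3)oc(=O)c12` gives 25.6 uM
Compound 3 `COc1cc(OC)cc(-c2cc3occ(C)c3c(=O)o2)c1` gives 65.4 uM

These three values all come from a functional assay on DU-145 cells (Homo sapiens) for cytotoxicity, read by sulforhodamine B assay, with a stated time of 72 h (a lower number here means that less compound is needed, a higher number that more compound is needed for the effect), and serve as the starting point here. On these numbers, compound 3 at 65.4 uM and compound 1 at 82.6 uM lie within the usual scatter of each other, while compound 2 at 25.6 uM needs clearly less compound than either.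

The question now is what happens on going from compound 3 to compound 4 `COc1cc(-c2cc3occ(C)c3c(=O)o2)cc(OC)c1OC` when one group is added. The change is methoxy in place of hydrogen on an aromatic carbon in short, methoxy in place of hydrogen on an aromatic carbon, ortho to two methoxy groups and para to a large group.

For the measured compounds named here, only one measured step resembles this: a 3.2-fold lower number from compound 1 to compound 2 (0.51 log units; beyond the scatter) when hydroxy takes the place of hydrogen on an aromatic carbon. That step is modest but beyond the scatter. Hydroxy is not methoxy, however, and no measured step adds a methoxy, so it is only a loose guide.

In this assay the expected result is a small move toward a lower number, estimated as a 1.5-fold lower number from compound 3 to compound 4 (0.16 log units; within the scatter) and so not beyond the scatter. For compound 4 the estimate is 45 uM as the expected value, with 15 uM to 110 uM as the expected range.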

Compound 4, concentration for half-maximal effect: > 63.3 uM
Compound 4 ended at the assay's limit (the forecaster's own chance of this, stated with the estimate: 10%); at least 1.4-fold (0.14 log units) between middle value and limit.
By their numbers in this assay, from the lowest: compound 2; then compounds 3 and 1 (each within the scatter of the next).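

Compound 4 gives > 63.3 uM, which is a limit of the assay and not a number, so the step between compound 3 and compound 4 cannot be read. The compounds shown leave open whether methoxy in place of hydrogen on this aromatic carbon changes the amount of compound needed in this assay, and by how much.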